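A Thiazole Ring in Place of Ethylphenyl

A few compounds are considered here, and "the series" means these few. Any claim that something is new, unique, unknown or untested is made for them only; others in the source may bear on it.

Three measured compounds share one core and differ only in the aryl group on a double-bonded chain carbon bound to a double-bonded chain carbon. In a functional assay on A-431 cells (Homo sapiens) for cytotoxicity (a lower number here means that less compound is needed, a higher number that more compound is needed for the effect), compound 1 `COC1=C(C)C(=O)/C(=C(O)/C=C/c2ccc(OC)cc2)C(=O)C1(C)C` gives 9.2 ug/mL, compound 2 `COC1=C(C)C(=O)/C(=C(O)/C=C/c2cccc(OC)c2)C(=O)C1(C)C` gives 4.5 ug/mL, and compound 3 `CCc1ccc(/C=C/C(O)=C2/C(=O)C(C)=C(OC)C(C)(C)C2=O)cc1` gives 12 ug/mL. Compound 3 has the highest of the three numbers; it lies within the scatter of compound 1, while the other gap is a larger one: a 2.7-fold higher number from compound 2 to compound 3 (0.43 log units; beyond the scatter). Compound 4 `COC1=C(C)C(=O)/C(=C(O)/C=C/c2nccs2)C(=O)C1(C)C` differs from compound 3 in one place: 1,3-thiazol-2-yl in place of 4-ethylphenyl on a double-bonded chain carbon bound to a double-bonded chain carbon. Going by the values given here, the steps of a 2.0-fold lower number from compound 1 to compound 2 (0.31 log units; beyond the scatter) and a 1.3-fold higher number from compound 1 to compound 3 (0.12 log units; within the scatter) bear on this change only loosely, since both keep a six-membered aromatic ring of carbon only; no measured step exchanges that ring for a five-membered aromatic ring with 2 hetero atoms, so the direction is not fixed by the data. The largest measured step is modest, and a change of about that size is the most the data support. Compound 4 is therefore expected to give roughly 13 ug/mL, estimated between 5 ug/mL and 32 ug/mL, an expected step of a 1.1-fold higher number from compound 3 to compound 4 (0.03 log units; within the scatter).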

Compound 4, concentration for half-maximal effect: 6 ug/mL
The estimate for compound 4 lay 2.2-fold (0.34 log units) above the measured number; the measured number falls inside the stated range.
By their numbers in this assay, from the lowest: compounds 2, 4, 1 and 3 (each within the scatter of the next, the first and the last beyond it).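

In this assay, a five-membered aromatic ring with 2 hetero atoms can stand on a double-bonded chain carbon bound to a double-bonded chain carbon with no step beyond the scatter, whichever six-membered aromatic ring of carbon only it replaces (4-ethylphenyl: a 2.0-fold lower number from compound 3 to compound 4 (0.30 log units; within the scatter); 3-methoxyphenyl: a 1.3-fold higher number from compound 2 to compound 4 (0.12 log units; within the scatter); 4-methoxyphenyl: a 1.5-fold lower number from compound 1 to compound 4 (0.19 log units; within the scatter)). Compound 4 thus lies within the scatter of compound 2 and of compound 3, two compounds that lie beyond the scatter of each other. No measurement is at hand that would explain this result.

Still open, going by these compounds, is whether a furan-2-yl or a pyridin-2-yl group at this place would give a number in the same range. Also open, on these data alone, is whether the ring nitrogen or the ring sulfur of 1,3-thiazol-2-yl matters to the number at all.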